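Compound 3 and its tetramethyl dioxolane counterpart

The compounds below may be only part of what the source reports. "The series", "measured", "known", "first", "only" and "open" are said of these compounds alone.

Compounds measured in a functional assay on A549 cells (Homo sapiens) for antiproliferative activity, read by sulforhodamine B assay, with a stated time of 72 h (a higher number here means a weaker inhibitor, a lower number a stronger inhibitor), so far:
- compound 1 `Cc1ccc(/C=C(\C(=O)O)C(C)C)c2c1CC[C@@H](C(C)(C)O)OC2=O` gives > 100000 nM, which is a limit
- compound 2 `Cc1ccc(/C=C(\C(=O)O)C(C)C)c2c1CC[C@H](C(C)(C)O)OC2=O` gives > 100000 nM, which is a limit
- compound 3 `CC(=O)Oc1cc2c(CC[C@@H](O)C(C)(C)O)c(C)ccc2cc1C(C)C` gives 48600 nM, which is a number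

In this assay compound 3 alone has a number, 48600 nM. Compound 1 and compound 2 have only limits.

Compound 4 `CC(=O)Oc1cc2c(CC[C@H]3OC(C)(C)OC3(C)C)c(C)ccc2cc1C(C)C` carries 2,2,5,5-tetramethyl-1,3-dioxolan-4-yl in place of 1,2-dihydroxy-2-methylpropyl, and the change in full is 2,2,5,5-tetramethyl-1,3-dioxolan-4-yl in place of 1,2-dihydroxy-2-methylpropyl on a saturated chain carbon, two bonds along the chain from an aromatic carbon.

Within the data shown here, the only measured step is a step that the two limits leave unreadable from compound 1 to compound 2, and it offers no size to carry over. It also concerns a different kind of change, given (the fact that compounds 1 and 2 differ only in the configuration as drawn). Among the measured compounds shown here, no measured step touches this group, so no direction can be claimed, and the expectation stays anchored on compound 3 at 48600 nM. With the limit of > 100000 nM in this assay, at which 2 of the 3 values shown sit, in view, a report of only a limit is also a real possibility.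

The expected change is a 1.0-fold higher number from compound 3 to compound 4 (0.01 log units; within the scatter), which is no more than the scatter. For compound 4 the estimated value is 50000 nM, with an expected range from 18000 nM to 100000 nM.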

Compound 4, half-maximal inhibitory concentration: 28900 nM
Compound 4: middle estimate off by 1.7-fold (0.24 log units), on the high side, and the stated range covers the measured number.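

In this assay, putting 2,2,5,5-tetramethyl-1,3-dioxolan-4-yl in place of 1,2-dihydroxy-2-methylpropyl on a saturated chain carbon, two bonds along the chain from an aromatic carbon, gives a 1.7-fold lower number from compound 3 to compound 4 (0.23 log units; within the scatter), and this is the only step shown with a readable size. The entering group has 9 heavy atoms against 6, one five-membered non-aromatic ring and 0 hydrogen-bond donors against 2, yet the two compounds remain within the usual scatter of each other. Nothing measured here bears on the size of this step.

The compounds shown leave open how an amine or a carboxylic acid at this place would read in this assay. They also leave open whether a longer chain carrying the same 1,2-dihydroxy-2-methylpropyl group would stay within the scatter of compound 3.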